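The compounds below may be only part of what the source reports. "The series", "measured", "known", "first", "only" and "open" are said of these compounds alone.

Measured so far:
compound 1, `Cc1ccc(N2CCN(C(=O)c3oc(C)nc3-c3ccccc3)CC2)c(C)c1`, in a functional assay on HL-60 cells (Homo sapiens) for inhibition, read by MTT assay, with a stated time of 72 h (a higher number here means a weaker inhibitor, a lower number a stronger inhibitor), compound 1 gives 101 nM.
compound 2, `Cc1nc(-c2ccccc2)c(C(=O)N2CCN(c3ccccc3Cl)CC2)o1`, in this assay compound 2 gives 124 nM.
compound 3, `CCOc1cccc(N2CCN(C(=O)c3oc(C)nc3-c3ccccc3)CC2)c1`, in this assay compound 3 gives 151 nM.

These three compounds share one core and differ only in the aromatic ring carried on an amine nitrogen in a ring. Compound 3 gives the highest of the three numbers, but a 1.5-fold higher number from compound 1 to compound 3 (0.17 log units; within the scatter) and a 1.2-fold higher number from compound 2 to compound 3 (0.09 log units; within the scatter) are both within the scatter, as is a 1.2-fold higher number from compound 1 to compound 2 (0.09 log units; within the scatter), so nothing separates the three in this assay.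

Compound 4, `Cc1nc(-c2ccccc2)c(C(=O)N2CCN(c3cccc(C#N)c3)CC2)o1`, is not yet measured. It differs from compound 3 in one place: cyano in place of ethoxy on an aromatic carbon. Every measured step here swaps one substituted aromatic ring for another at the same position, and every one of them stayed within the scatter. The change to compound 4 is of the same kind, so the expected step of a 1.0-fold lower number from compound 3 to compound 4 (0.00 log units; within the scatter) is likewise within the scatter, with no clear direction. On that basis compound 4 is estimated at 150 nM in this assay, with a range from 70 nM to 320 nM.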

Compound 4, half-maximal inhibitory concentration: 39.6 nM
Compound 4: the middle estimate sits 3.8-fold (0.58 log units) above what was measured; the whole stated range lies above it.
By their numbers in this assay, from the lowest: compound 4; then compounds 1, 2 and 3 (each within the scatter of the next).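

Until now, every swap of the aromatic ring on the amine nitrogen stayed within the scatter, so this position seemed to tolerate any of the rings tried. Going by these compounds alone, the change from ethoxy to cyano on an aromatic carbon is the first to separate two compounds, with a 3.8-fold lower number from compound 3 to compound 4 (0.58 log units; beyond the scatter) in this assay. The 3-cyanophenyl ring also stands apart from the other two rings, with a 3.1-fold lower number from compound 2 to compound 4 (0.50 log units; beyond the scatter) and a 2.6-fold lower number from compound 1 to compound 4 (0.41 log units; beyond the scatter), which makes compound 4 the strongest inhibitor of the four, although no measurement shown here explains the difference.

Going by these compounds, the nitrile appears in only one place, meta to a large group, so it remains open whether the lower number depends on that placement or would survive a move to another carbon of the ring. On these data alone, it is also open whether another group in the same place, such as an amine, a carboxylic acid or a longer chain, would match compound 4 or fall back among the other three compounds.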